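Moving from 4-bromophenyl to 3-chlorophenyl at the assay limit

The source may hold more compounds than are shown below. What is called first, only, known or untested is meant among the compounds shown, and "the series" means these compounds.

Compound 1 `COc1ccc(/C=C/C(=O)/C=C/c2cc3ccccc3nc2Oc2ccc(Br)cc2)cc1` and compound 2 `COc1cc(OC)c(/C=C/C(=O)/C=C/c2cc3ccccc3nc2Oc2ccc(Br)cc2)c(OC)c1` share one core and were both read in a functional assay on HeLa cells (Homo sapiens) for cytotoxicity, read by MTT assay, with a stated time of 48 h; a lower number here means a stronger inhibitor, a higher number a weaker inhibitor. Compound 1 gives > 10000 nM, which is a limit of the assay and not a number. Compound 2 gives > 10000 nM, which is likewise a limit. Compound 2 therefore gives no exact starting point and stands with compound 1 at the limit of > 10000 nM in this assay, at which 2 of the 2 values shown sit. Compound 3 `COc1cc(OC)c(/C=C/C(=O)/C=C/c2cc3ccccc3nc2Oc2cccc(Cl)c2)c(OC)c1` differs from compound 2 by 3-chlorophenyl in place of 4-bromophenyl on an oxygen on an aromatic ring. Among the measured compounds shown here, the only measured step is a step that the two limits leave unreadable from compound 1 to compound 2, made at a different place, so it offers no size to carry over. Because of the limit of > 10000 nM in this assay, at which 2 of the 2 values shown sit, compound 3 is expected to stay weak in this assay, with no firm direction. The estimated change is a step that the limit leaves unreadable from compound 2 to compound 3. For compound 3 the expected value is 15000 nM, with an expected range of 6000 nM to 40000 nM.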

Compound 3, half-maximal inhibitory concentration: > 10000 nM
Compound 3: a limit, no number; the forecaster's own chance of this, stated with the estimate: 80%; the middle value lies beyond the limit too.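

Compound 3 gives > 10000 nM in this assay, a limit of the assay and not a number, so the change from compound 2 to compound 3 has no readable size. Still open is whether 4-bromophenoxy and 3-chlorophenoxy differ at all in this test, and how active any of the three compounds really is, since the data offer only this: the limit of > 10000 nM in this assay, at which 3 of the 3 values shown sit.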